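Thiourea Analogue with a Dimethoxypyrimidine Headgroup

The compounds below may be only part of what the source reports. "The series", "measured", "known", "first", "only" and "open" are said of these compounds alone.

compound 1, `COc1cc(C)nc2n/c(=N/C(=O)c3c(-c4ccc(Cl)cc4Cl)noc3C)sn12`: 80.6%
compound 2, `Cc1cc(Cl)nc(NC(=S)NC(=O)c2c(-c3ccc(Cl)cc3Cl)noc2C)n1`: 44.2%

Of the compounds shown here, two have been measured in a functional assay on the whole organism for inhibition, with Digitaria ciliaris as the target, with a stated time of 72 h, tested at 100 mg/L; a lower number here means less inhibition of growth, a higher number more inhibition of growth at the concentration tested. Compound 1 `COc1cc(C)nc2n/c(=N/C(=O)c3c(-c4ccc(Cl)cc4Cl)noc3C)sn12` gives 80.6% in this assay, while compound 2 `Cc1cc(Cl)nc(NC(=S)NC(=O)c2c(-c3ccc(Cl)cc3Cl)noc2C)n1` gives 44.2%. Compound 2 therefore stands lowest of the two numbers; its nearest neighbour is compound 1, which lies higher by a margin beyond the scatter. The two compounds differ in more than one place, so no single step can be read from them, and only what their two values show can be said.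

Compound 3 `COc1cc(OC)nc(NC(=S)NC(=O)c2c(-c3ccc(Cl)cc3Cl)noc2C)n1` differs from compound 2 in one place: 4,6-dimethoxypyrimidin-2-yl in place of 4-chloro-6-methylpyrimidin-2-yl on an amide-type nitrogen. Among the measured compounds shown here, no measured pair reports what this exchange does, so the size and direction of the step rest on the structural change alone. A moderate rise from compound 2 is expected, with the step of a number 13.8 percentage points higher from compound 2 to compound 3 (beyond the scatter) estimated to lie beyond the scatter but well short of the gap that separates compound 2 from compound 1. Compound 3 is expected to give about 58% in this assay, with the estimate ranging from 32% to 82%.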

Compound 3, percent growth inhibition at one concentration: 65.9%
Compound 3: the middle estimate sits 7.9 percentage points below what was measured; the measured number falls inside the stated range.
By their numbers in this assay, from the lowest: compound 2; then compound 3; then compound 1.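

In this assay, among the compounds shown here, the exchange of 4-chloro-6-methylpyrimidin-2-yl for 4,6-dimethoxypyrimidin-2-yl on the amide-type nitrogen gives a number 21.7 percentage points higher from compound 2 to compound 3 (beyond the scatter) and provides the first reading from a pair that differs in one place. It shows that this position, where the nitrogen's other neighbour is the thiocarbonyl carbon, is sensitive to the substituents on the pyrimidine ring: with the rest of the structure unchanged, these two aromatic groups are not interchangeable. Nothing measured here explains the step.

Both ring substituents change together in this exchange, so the pair cannot show how much of the step belongs to the loss of chlorine, the loss of methyl or the arrival of either methoxy group; 4-methoxy-6-methylpyrimidin-2-yl and 4-chloro-6-methoxypyrimidin-2-yl would separate these contributions. Going by these compounds, it also remains open whether an amino group or a longer ethoxy chain on the pyrimidine would continue the step, and whether the same exchange would have a comparable effect on the core of compound 1.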